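Ethyl in Place of Trifluoromethyl

The source may report more compounds than this note shows. Statements on the series, on what has been measured and on what is new or still open speak of the compounds shown alone.

In a functional assay on the whole organism for inhibition, with Rattus norvegicus as the target (on this read-out higher numbers stand for an effect only at larger amounts of compound and lower numbers for an effect already at smaller amounts), compound 1 `COc1ccc(CC(Oc2ccc(C(C)C)cc2)C(=O)O)cc1` is reported only as a limit, > 50 mg/kg. Among the measured compounds shown here, compound 2 `CC(C)c1ccc(OC(C)(Cc2cccc(C(F)(F)F)c2)C(=O)O)cc1` gives 5 mg/kg, the only actual number available in this assay. Compound 3 `CCc1cccc(CC(C)(Oc2ccc(C(C)C)cc2)C(=O)O)c1` has ethyl in place of trifluoromethyl on an aromatic carbon. For the measured compounds named here, no measured step between closely matched compounds is available to size this change. In this assay, no step beyond the usual scatter is expected, with a slight lean toward larger doses. The estimated step is a 1.6-fold higher number from compound 2 to compound 3 (0.20 log units; within the scatter). For compound 3, the estimated dose is 8 mg/kg, with an expected range of 3 mg/kg to 25 mg/kg.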

Compound 3, dose for half-maximal effect: 0.5 mg/kg
Compound 3: the middle estimate sits 16-fold (1.20 log units) above what was measured; measured number below the stated range.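

In this assay, among the compounds shown here, the aromatic carbon meta to a large group proves sensitive to what it carries, which no earlier compound could show: ethyl in place of trifluoromethyl gives a 10-fold lower number from compound 2 to compound 3 (1.00 log units; beyond the scatter). Trifluoromethyl is therefore not needed at this place for an effect at low doses on this core. Compound 1 alone stands as a limit, so the step rests on two actual numbers: the limit of > 50 mg/kg in this assay, at which 1 of the 3 values shown sits.

Going by these compounds, how a methyl, a propyl chain or a chlorine would fare at this place stays open. So does whether the step would hold on another core.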